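This account rests on a few compounds, and the source may have more. Where it says the series, first, only, none or still open, it means among the compounds named here.

Compound 2 `O=C(O)c1cc(-c2cccc(COc3ccc4c(c3)CN(Cc3ccc(C(F)(F)F)cc3)C4=O)c2)ccc1Cl` and compound 1 `O=C(O)c1cc(-c2cccc(COc3ccc4c(c3)CN(CC3CC3)C4=O)c2)ccc1Cl` share one core and differ only in the group on the amide-type nitrogen in a ring. Among the compounds with values here, in an assay on HEK293 cells for positive allosteric modulation of metabotropic glutamate receptor 2 (Rattus norvegicus), read by thallium flux (a lower number here means that less compound is needed, a higher number that more compound is needed for the effect), compound 1 gives 80 nM, and in this assay compound 2 gives 350 nM, the highest of the two numbers measured so far. That gap is the step of a 4.4-fold higher number from compound 1 to compound 2 (0.64 log units; beyond the scatter). Compound 3 `O=C(O)c1cc(-c2cccc(COc3ccc4c(c3)CN(C3CCC3)C4=O)c2)ccc1Cl` has not yet been measured; it differs from compound 2 by cyclobutyl in place of 4-(trifluoromethyl)benzyl on an amide-type nitrogen in a ring. Within the data shown here, the only measured step that bears on this change is a 4.4-fold higher number from compound 1 to compound 2 (0.64 log units; beyond the scatter), which ran in the opposite direction when cyclopropyl gave way to 4-(trifluoromethyl)benzyl. Compound 3 is expected to move back toward compound 1 because the cyclopropyl-bearing compound 1 gives 80 nM, so a step of a 3.2-fold lower number from compound 2 to compound 3 (0.50 log units; beyond the scatter) in this assay is expected. The estimate for compound 3 in this assay is 110 nM, within a range from 40 nM to 300 nM.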

Compound 3, half-maximal effective concentration: 90 nM
The estimate for compound 3 lay 1.2-fold (0.09 log units) above the measured number; low and high end bracket the measured number.
By their numbers in this assay, from the lowest: compounds 1 and 3 (each within the scatter of the next); then compound 2.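

In this assay, the step of a 3.9-fold lower number from compound 2 to compound 3 (0.59 log units; beyond the scatter) shows that the higher number of compound 2 is not set by the shared core alone, since changing only the group on the amide-type nitrogen in a ring brings the number down again. Within the data shown here, the step of a 1.1-fold higher number from compound 1 to compound 3 (0.05 log units; within the scatter) lies within the scatter, so cyclobutyl bound directly to this nitrogen and cyclopropylmethyl cannot be told apart here, which leaves 4-(trifluoromethyl)benzyl as the one group of the three that stands apart. Nothing measured here explains this difference.

From the compounds shown here alone, it remains open whether the number of compound 2 follows from the aromatic ring or from its trifluoromethyl, a question a plain benzyl group would help to separate. Also open, going by these compounds, is how an amine, a hydroxyl or a longer carbon chain would read on this nitrogen.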